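This account rests on a few compounds, and the source may have more. Where it says the series, first, only, none or still open, it means among the compounds named here.

Among the measured compounds shown here, compound 3 `COc1ccc(CNCCCNS(=O)(=O)c2cc(C(F)(F)F)cc(C(F)(F)F)c2)cc1` gives 2900 nM in a functional assay on HT-29 cells (Homo sapiens) for inhibition, read by MTT assay, with a stated time of 72 h (a higher number here means a weaker inhibitor of growth, a lower number a stronger inhibitor of growth), the second highest of the three numbers measured so far. Compound 1 `O=S(=O)(NCCCNCC1COc2ccccc2O1)c1cc(C(F)(F)F)cc(C(F)(F)F)c1` gives 2200 nM in this assay, and the step of a 1.3-fold higher number from compound 1 to compound 3 (0.12 log units; within the scatter) lies within the scatter. Compound 2 `O=S(=O)(NCCCNCc1ccccc1)c1cc(C(F)(F)F)cc(C(F)(F)F)c1` gives 15000 nM in this assay. The step of a 5.2-fold lower number from compound 2 to compound 3 (0.71 log units; beyond the scatter) shows that a methoxy group on the aromatic ring lowered the number beyond the scatter. Compound 4 `COc1cccc(CNCCCNS(=O)(=O)c2cc(C(F)(F)F)cc(C(F)(F)F)c2)c1` differs from compound 3 by 3-methoxyphenyl in place of 4-methoxyphenyl on a saturated chain carbon bound to an amine nitrogen. For the measured compounds named here, no measured step moves the methoxy group from one place on the ring to another, so the measured steps show that a methoxy group matters but say nothing about where. A step within the scatter, a 1.2-fold higher number from compound 3 to compound 4 (0.08 log units; within the scatter), is therefore expected. Compound 4 is estimated at 3500 nM, with a range from 1500 nM to 9000 nM.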

Compound 4, concentration for 50% growth inhibition: 10000 nM
For compound 4 the middle estimate is 2.9-fold (0.46 log units) below the measured one; measured number outside the range, above it.
By their numbers in this assay, from the lowest: compounds 1 and 3 (each within the scatter of the next); then compounds 4 and 2 (each within the scatter of the next).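

Moving the methoxy group on the ring matters in this assay, giving a 3.4-fold higher number from compound 3 to compound 4 (0.54 log units; beyond the scatter). As 3-methoxyphenyl, the added methoxy group gives only a 1.5-fold lower number from compound 2 to compound 4 (0.18 log units; within the scatter), so the benefit seen with 4-methoxyphenyl is not shared, while replacing 2,3-dihydro-1,4-benzodioxin-2-yl gives a 4.5-fold higher number from compound 1 to compound 4 (0.66 log units; beyond the scatter). No measurement available here explains why the two methoxyphenyl groups differ. Still open, on these data alone, is whether a hydroxy group or a chlorine atom on the phenyl ring would show the same dependence on position, and whether a longer chain would change it.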